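A few compounds are considered here, and "the series" means these few. Any claim that something is new, unique, unknown or untested is made for them only; others in the source may bear on it.

Compound 1 `COc1cc(N)c(Cl)cc1C(=O)CCC1CCN(CCNS(=O)(=O)c2cc(Br)ccc2Br)CC1`: 16%
Compound 2 `COc1cc(N)c(Cl)cc1C(=O)CCC1CCN(CCNS(=O)(=O)c2ccc(N)c(Br)c2)CC1`: 39%
Compound 3 `COc1ccc(S(=O)(=O)NCCN2CCC(CCC(=O)c3cc(Cl)c(N)cc3OC)CC2)c(OC)c1`: "not active" (no number reported)

In an assay on HEK293 cells for displacement of a labelled ligand from 5-hydroxytryptamine receptor 6 (Homo sapiens), with a stated time of 60 min, tested at 0.01 uM, in the presence of a further agent that is not named here (a lower number here means a weaker effect, a higher number a stronger effect of the compound at the concentration tested), compound 3 is reported as "not active" (no number reported), so no single number is known for it. Compound 4 `COc1cc(N)c(Cl)cc1C(=O)CCC1CCN(CCNS(=O)(=O)c2ccc(NC(C)=O)cc2)CC1` differs from compound 3 by 4-acetamidophenyl in place of 2,4-dimethoxyphenyl on a sulfonyl sulfur. Among the compounds with values here, the only measured step at the same place is a number 23 percentage points higher from compound 1 to compound 2 (beyond the scatter), a modest rise for a different pair of groups on the sulfonyl sulfur. That step shows that changing the group there can move the read-out in this assay by a modest amount; it gives no direct guidance for replacing 2,4-dimethoxyphenyl with 4-acetamidophenyl. Compound 4 is therefore expected to show a weak effect, estimated at 20%, with a likely range from 2% to 45%.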

Compound 4, a percentage reported as inhibition, at one concentration (the size of the read-out at that concentration, not a potency): 7%
Compound 4: middle estimate off by 13 percentage points, on the high side; the range from low to high includes it.
By their numbers in this assay, from the lowest: compounds 4 and 1 (each within the scatter of the next); then compound 2.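

In this assay, a change on the sulfonyl sulfur can also bring the number down sharply (a number 32 percentage points lower from compound 2 to compound 4 (beyond the scatter)), whereas 4-acetamidophenyl and 2,5-dibromophenyl cannot be told apart (a number 9 percentage points lower from compound 1 to compound 4 (within the scatter)). Only compound 2, with 4-amino-3-bromophenyl, stands clear of both, and nothing available here explains this.

Compound 3 has no number, so its step to compound 4 cannot be read. On these data alone, it also remains open what an aminophenyl group without bromine, or a bromophenyl group without the amine, would give on the sulfonyl sulfur.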